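The source may report more compounds than this note shows. Statements on the series, on what has been measured and on what is new or still open speak of the compounds shown alone.

Among the measured compounds shown here, in a functional assay on MKN-45 cells (Homo sapiens) for cytotoxicity, read by MTT assay, with a stated time of 72 h (a lower number here means a stronger inhibitor, a higher number a weaker inhibitor), compound 2 `COc1ccc(/C=N/NC(=O)Nc2ccc(Oc3ccnc4cc(OCCCN5CCCCC5)c(OC)cc34)c(F)c2)c(OC)c1` gives 1990 nM, the highest of the two numbers known here. For the measured compounds named here, its only neighbour, compound 1 `COc1cc2c(Oc3ccc(NC(=O)N/N=C/c4ccc(C(F)(F)F)cc4)cc3F)ccnc2cc1OCCCN1CCCCC1`, gives 630 nM in this assay, and the single step between the two, a 3.2-fold higher number from compound 1 to compound 2 (0.50 log units; beyond the scatter), exchanges the aryl group on the carbon with a double bond to nitrogen. Compound 3 `COc1cc2c(Oc3ccc(NC(=O)N/N=C/c4ccc(N(C)C)cc4)cc3F)ccnc2cc1OCCCN1CCCCC1` has not yet been measured in this assay. It differs from compound 2 in one place: 4-(dimethylamino)phenyl in place of 2,4-dimethoxyphenyl on a carbon with a double bond to nitrogen. Going by the values given here, the only measured step that bears on this position is a 3.2-fold higher number from compound 1 to compound 2 (0.50 log units; beyond the scatter), which shows that exchanging the aryl group there moves the number by a modest amount. Among the compounds with values here, no measured pair shows the effect of the 4-(dimethylamino)phenyl group itself, so the direction for compound 3 rests only on the observation that the position responds to such exchanges, and a move back toward the number of compound 1 seems the more likely outcome. Compound 3 is therefore expected to give about 900 nM in this assay, within the range 300 nM to 2700 nM, which would mean an expected step of a 2.2-fold lower number from compound 2 to compound 3 (0.34 log units; beyond the scatter).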

Compound 3, half-maximal inhibitory concentration: 870 nM
Compound 3: the middle estimate sits 1.0-fold (0.01 log units) above what was measured; the range from low to high includes it.
By their numbers in this assay, from the lowest: compounds 1 and 3 (each within the scatter of the next); then compound 2.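

Compound 3 shows that the aryl group on the carbon with a double bond to nitrogen can be exchanged in either direction in this assay: replacing 2,4-dimethoxyphenyl with 4-(dimethylamino)phenyl brings the number down by a modest amount (a 2.3-fold lower number from compound 2 to compound 3 (0.36 log units; beyond the scatter)), so the earlier rise was not a general cost of changing away from 4-(trifluoromethyl)phenyl. The second comparison adds that dimethylamino in place of trifluoromethyl on the aromatic carbon leaves the two compounds indistinguishable (a 1.4-fold higher number from compound 1 to compound 3 (0.14 log units; within the scatter)), and among these three aryl groups only the 2,4-dimethoxyphenyl of compound 2 sets its compound apart beyond the scatter. No measurement in hand accounts for either of these outcomes.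

The compounds shown leave open whether the two methoxy groups of compound 2 act together or whether one of them alone would give the same number, which a phenyl ring bearing a single methoxy group could separate. As far as these compounds go, they also leave open what an unsubstituted phenyl ring or a phenyl ring carrying a carboxylic acid would give at this position, so the range of the response remains unknown beyond these three aryl groups.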